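The source may report more compounds than this note shows. Statements on the series, on what has been measured and on what is new or still open speak of the compounds shown alone.

Compound 1 `N#C[Se]c1ccc(NC(=O)Oc2ccccc2)cc1`: 41700 nM
Compound 2 `N#C[Se]c1ccc(NC(=O)Oc2ccc(Cl)cc2)cc1`: 40300 nM

In a functional assay on HT-29 cells (Homo sapiens) for cytotoxicity, read by MTT assay, with a stated time of 72 h (a higher number here means a weaker inhibitor of growth, a lower number a stronger inhibitor of growth), compound 1 gives 41700 nM, and compound 2 gives 40300 nM; the two sit at the same level, so compound 2 stands within the scatter of compound 1. For the measured compounds named here, the single measured step, a 1.0-fold lower number from compound 1 to compound 2 (0.01 log units; within the scatter), shows that a change at this position made no difference beyond the scatter. Compound 3 `COc1ccc(OC(=O)Nc2ccc([Se]C#N)cc2)cc1` differs from compound 2 by methoxy in place of chloro on an aromatic carbon. Because this change falls at the same position as a 1.0-fold lower number from compound 1 to compound 2 (0.01 log units; within the scatter), no shift beyond the scatter is expected in this assay. For compound 3 the expected step is a 1.0-fold lower number from compound 2 to compound 3 (0.00 log units; within the scatter), and the estimate is 40000 nM, within 20000 nM to 80000 nM.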

Compound 3, concentration for total growth inhibition: 41500 nM
The estimate for compound 3 lay 1.0-fold (0.02 log units) below the measured number, and the stated range covers the measured number.
By their numbers in this assay, from the lowest: compounds 2, 3 and 1 (each within the scatter of the next).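

In this assay the step of a 1.0-fold higher number from compound 2 to compound 3 (0.01 log units; within the scatter) and the step of a 1.0-fold lower number from compound 1 to compound 3 (0.00 log units; within the scatter) both lie within the scatter, so methoxy on this aromatic carbon, para to a large group, sits at the same level as both chloro and hydrogen. Until now only chloro had been compared with hydrogen here, whereas methoxy adds a second kind of group, with two heavy atoms and a hydrogen-bond acceptor, and still produces no shift beyond the scatter. Going by these compounds, whether an amine or a carboxylic acid at this position would move the number beyond the scatter remains open, as does the effect of a change elsewhere in the shared core. Nothing measured here explains why these three groups sit at one level.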